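The compounds below may be only part of what the source reports. "The series", "measured", "known", "first", "only" and "open" are said of these compounds alone.

Measured so far:
compound 1 `Cn1c(=O)c(=O)n(C2CCCC2)c2nc(N/N=C/c3ccc(F)c(Cl)c3)ncc21`, 8550 nM
compound 2 `Cn1c(=O)c(=O)n(C2CCCC2)c2nc(N/N=C/c3ccc(O)c(F)c3)ncc21`, 85200 nM
compound 3 `Cn1c(=O)c(=O)n(C2CCCC2)c2nc(N/N=C/c3ccc(C(F)(F)F)cc3)ncc21`, 23600 nM

In a functional assay on PC-3 cells (Homo sapiens) for antiproliferative activity, read by MTT assay (a higher number here means a weaker inhibitor, a lower number a stronger inhibitor), compound 1 gives the lowest number of the three, with compound 3 nearest to it and compound 2 furthest away. Compound 4 `Cn1c(=O)c(=O)n(C2CCCC2)c2nc(N/N=C/c3cccc(O)c3)ncc21` differs from compound 1 in one place: 3-hydroxyphenyl in place of 3-chloro-4-fluorophenyl on a carbon with a double bond to nitrogen. Two measured steps leave compound 1 and bear on this change. The step of a 10-fold higher number from compound 1 to compound 2 (1.00 log units; beyond the scatter) also brings in a hydroxyl on the ring, while the step of a 2.8-fold higher number from compound 1 to compound 3 (0.44 log units; beyond the scatter) swaps the halogen pair for another group. Both move toward higher numbers, so compound 4 is expected to be a weaker inhibitor than compound 1, with a step of a 4.1-fold higher number from compound 1 to compound 4 (0.61 log units; beyond the scatter). For compound 4 the estimate is 35000 nM, within a range from 10000 nM to 100000 nM.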

Compound 4, half-maximal inhibitory concentration: 36300 nM
The estimate for compound 4 lay 1.0-fold (0.02 log units) below the measured number, and the stated range covers the measured number.
By their numbers in this assay, from the lowest: compound 1; then compounds 3 and 4 (each within the scatter of the next); then compound 2.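

In this assay, 3-hydroxyphenyl on this carbon gives a 4.2-fold higher number from compound 1 to compound 4 (0.63 log units; beyond the scatter), so a ring carrying a hydroxyl and no halogen also stays on the weaker side of 3-chloro-4-fluorophenyl, yet the result with 3-fluoro-4-hydroxyphenyl does not set the limit for hydroxyl-bearing rings, as a 2.3-fold lower number from compound 2 to compound 4 (0.37 log units; beyond the scatter) shows. The 3-hydroxyphenyl ring is not separated from 4-(trifluoromethyl)phenyl, with a 1.5-fold higher number from compound 3 to compound 4 (0.19 log units; within the scatter). Nothing at hand gives a reason for these steps. The compounds shown leave open how a methoxy group, an amine or a carboxylic acid on this ring would compare with 3-chloro-4-fluorophenyl.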